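Swapping the Benzoyl on Compound 3 for an Indolylmethyl

This account rests on a few compounds, and the source may have more. Where it says the series, first, only, none or still open, it means among the compounds named here.

Three compounds share one core, and compound 3 `O=C(c1ccccc1)N1CCC(NCCSC(c2ccc(F)cc2)c2ccc(F)cc2)CC1` gives 4.51 nM in an assay on membranes from striatum (strain Sprague-Dawley) for displacement of a labelled ligand from sodium-dependent dopamine transporter (Rattus norvegicus), read by scintillation counting, with a stated time of 120 min; a lower number here means a stronger inhibitor, a higher number a weaker inhibitor. That is the lowest of the three numbers: compound 1 `OC(Cc1ccccc1)CN1CCC(NCCSC(c2ccc(F)cc2)c2ccc(F)cc2)CC1` gives 31.4 nM, and compound 2 `[O-][S+](CCNC1CCN(CC(O)Cc2ccccc2)CC1)C(c1ccc(F)cc1)c1ccc(F)cc1` gives 91.8 nM. Among the compounds with values here, the one single-point step measured so far, a 7.0-fold lower number from compound 1 to compound 3 (0.84 log units; beyond the scatter), shows that the group on the ring amine nitrogen can move the number by a modest amount beyond the scatter.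

Compound 4 `Fc1ccc(C(SCCNC2CCN(Cc3cc4ccccc4[nH]3)CC2)c2ccc(F)cc2)cc1` changes that same position again: (1H-indol-2-yl)methyl in place of benzoyl on an amine nitrogen in a ring. Within the data shown here, no measured step involves the (1H-indol-2-yl)methyl group, so the one step from compound 1 to compound 3 only tells how much this position has mattered, not which way this new group will go. Compound 4 is therefore expected to stay close to compound 3, with a step of about a 2.7-fold higher number from compound 3 to compound 4 (0.43 log units; beyond the scatter) in this assay and a wide range allowed. The estimate for compound 4 in this assay is 12 nM, expected between 3 nM and 50 nM.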

Compound 4, inhibition constant: 179 nM
Compound 4: the middle estimate sits 15-fold (1.17 log units) below what was measured, outside the stated range (above it).
By their numbers in this assay, from the lowest: compound 3; then compound 1; then compounds 2 and 4 (each within the scatter of the next).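

In this assay, within the data shown here, replacing benzoyl with (1H-indol-2-yl)methyl on the ring amine nitrogen gives a 40-fold higher number from compound 3 to compound 4 (1.60 log units; beyond the scatter), so this position can shift the number much further than the earlier compounds showed, and the shift here is towards a weaker inhibitor. The same group also compares poorly with the 2-hydroxy-3-phenylpropyl group, giving a 5.7-fold higher number from compound 1 to compound 4 (0.76 log units; beyond the scatter); of the three groups on this nitrogen in compound 1, compound 3 and compound 4, it carries the highest number. No measurement shown here offers a reason for this loss.

The compounds shown leave open whether a plain benzyl group would land nearer compound 3 or compound 4. A 1H-indol-2-yl group joined through a carbonyl would be a further test, helping to separate the role of the carbonyl from that of the added ring.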